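The source may hold more compounds than are shown below. What is called first, only, known or untested is meant among the compounds shown, and "the series" means these compounds.

Measured so far in an ADME assay on the whole organism with Oryza sativa as the target, tested at 10 uM; a higher number here means a weaker effect of the compound at the concentration tested, a lower number a stronger effect:
- compound 1, `CCCc1ccc(NC(=O)N[C@H](C)c2ccccc2)cc1`: 35%
- compound 2, `CCCCc1ccc(NC(=O)N[C@H](C)c2ccccc2)cc1`: 28%
- compound 3, `CCCCc1ccc(NC(=O)N[C@@H](C)c2ccccc2)cc1`: 60%

Compound 2 stands lowest of the three numbers. The gap to compound 1, a number 7 percentage points lower from compound 1 to compound 2 (within the scatter), lies within the scatter, so the two are not told apart. The gap to compound 3, a number 32 percentage points higher from compound 2 to compound 3 (beyond the scatter), is large and lies beyond it; that step turns on configuration alone, because of the fact that compounds 2 and 3 differ only in the configuration as drawn.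

Compound 4, `CCOC(=O)c1ccc(NC(=O)N[C@H](C)c2ccccc2)cc1`, has not yet been measured in this assay. Relative to compound 2 the change is ethoxycarbonyl in place of butyl on an aromatic carbon. The configuration drawn in compound 2 is kept.

Of the measured steps, only the chain change from compound 1 to compound 2 touches the same aromatic position, and it was within the scatter, a number 7 percentage points lower from compound 1 to compound 2 (within the scatter). The configuration step from compound 2 to compound 3 does not bear on this change. For the measured compounds named here, no measured step replaces an alkyl chain with an ethoxycarbonyl, so the step in this assay from compound 2 to compound 4 cannot be anchored to a precedent; the expectation is a number near that of compound 2 with a wide range, a number 12 percentage points higher from compound 2 to compound 4 (beyond the scatter).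

Compound 4 is therefore estimated at 40%, with a range from 20% to 65%.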

Compound 4, a percentage reported as activity, at one concentration (the size of the read-out at that concentration, not a potency): 92%
The estimate for compound 4 lay 52 percentage points below the measured number; measured number outside the range, above it.
By their numbers in this assay, from the lowest: compounds 2 and 1 (each within the scatter of the next); then compound 3; then compound 4.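

In this assay the aromatic carbon para to a large group proves sensitive to the kind of group it carries, not only to chain length: ethoxycarbonyl in place of butyl gives a number 64 percentage points higher from compound 2 to compound 4 (beyond the scatter), and ethoxycarbonyl in place of propyl gives a number 57 percentage points higher from compound 1 to compound 4 (beyond the scatter). The earlier alkyl pair showed only that propyl and butyl are not told apart here, with a number 7 percentage points lower from compound 1 to compound 2 (within the scatter), and the two new steps show that this tolerance does not extend to every group at this carbon, since the number rises and the effect at the tested concentration weakens. Nothing on record gives a measured property that accounts for these two steps.

The compounds shown leave open whether a group such as a carboxylic acid, a primary amide, a methoxy or a longer alkyl chain on this carbon would stay with the alkyl compounds or move towards compound 4. Also open, from the compounds shown here alone, is whether the configuration step seen with butyl, a number 32 percentage points higher from compound 2 to compound 3 (beyond the scatter), carries over when ethoxycarbonyl occupies this carbon.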